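A few compounds are considered here, and "the series" means these few. Any claim that something is new, unique, unknown or untested is made for them only; others in the source may bear on it.

Working notes on the series, read in a functional assay on KBVIN cells (Homo sapiens) for antiproliferative activity, read by sulforhodamine B assay, with a stated time of 3 days; on this read-out lower numbers stand for an effect already at smaller amounts and higher numbers for an effect only at larger amounts of compound. Compound 1 `CCCC1=C(OC)C(CCC)(CCC)C(=O)/C(=C(O)\C=C\c2ccc(I)cc2)C1=O` gives 1.4 uM and compound 2 `CCCOC1=C(CCC)C(=O)/C(=C(O)/C=C/c2ccccc2)C(=O)C1(CCC)CCC` gives 2.4 uM. Within the data shown here, these two values lie within the usual scatter of each other, so no order can be read between them, and compound 2 stands level with the only other measured member.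

Compound 3 `CCCOC1=C(CCC)C(=O)/C(=C(O)/C=C/c2ccc(I)cc2)C(=O)C1(CCC)CCC` has not yet been measured. It differs from compound 2 in one place: iodo in place of hydrogen on an aromatic carbon. This is iodo in place of hydrogen on an aromatic carbon, para to a large group, and it turns the phenyl into 4-iodophenyl.

Among the measured compounds shown here, no measured pair isolates this change, so the data give no direct size for it. Compound 1 already bears a 4-iodophenyl on a differently substituted core and gives 1.4 uM, which offers no reason to expect a large move in either direction. The expected step of a 1.5-fold lower number from compound 2 to compound 3 (0.18 log units; within the scatter) is small, slightly toward a lower number and not beyond the scatter. For compound 3 the estimated value is 1.6 uM, with an expected range of 0.6 uM to 4 uM.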

Compound 3, concentration for half-maximal effect: 6.2 uM
Compound 3: the middle estimate sits 3.9-fold (0.59 log units) below what was measured; measured number above the stated range.
By their numbers in this assay, from the lowest: compounds 1 and 2 (each within the scatter of the next); then compound 3.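

In this assay, iodo in place of hydrogen on an aromatic carbon, para to a large group, is not a silent change on this core: phenyl to 4-iodophenyl gives a 2.6-fold higher number from compound 2 to compound 3 (0.41 log units; beyond the scatter), a move to a higher number that the earlier pair could not reveal, since compound 1 and compound 2 differ in more than one place and stand level. With the 4-iodophenyl held in common, ethyl in place of hydrogen on a saturated chain carbon bound to an oxygen on an unsaturated carbon gives a 4.4-fold higher number from compound 1 to compound 3 (0.65 log units; beyond the scatter), so the outcome for 4-iodophenyl depends on what else the core carries, at least across these two compounds. Nothing measured here accounts for either step.

From the compounds shown here alone, whether the step from compound 2 to compound 3 belongs to iodo in particular remains open, and a chloro or a methoxy at the same place on the ring would help to settle it. Also open, going by these compounds, is whether iodo in place of hydrogen gives a step of similar size and direction on the core of compound 1.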